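A few compounds are considered here, and "the series" means these few. Any claim that something is new, unique, unknown or untested is made for them only; others in the source may bear on it.

Measured so far in a physicochemical assay for solubility, read by HPLC; a higher number here means a more soluble compound, a lower number a less soluble compound:
- compound 1, `O=C(c1cccc(F)c1)N1CCN(c2nc(=O)c3cc(C(F)(F)F)cc([N+](=O)[O-])c3s2)CC1`: 0.2 ug/mL
- compound 2, `CCC(C)C(=O)N1CCN(c2nc(=O)c3cc(C(F)(F)F)cc([N+](=O)[O-])c3s2)CC1`: 104 ug/mL

Compound 1 stands lowest of the two numbers. Compound 3, `O=C(C1CCCC1)N1CCN(c2nc(=O)c3cc(C(F)(F)F)cc([N+](=O)[O-])c3s2)CC1`, is not yet measured. It differs from compound 1 in one place: cyclopentyl in place of 3-fluorophenyl on a carbonyl carbon. Within the data shown here, the only measured step that bears on this change is a 520-fold higher number from compound 1 to compound 2 (2.72 log units; beyond the scatter), where an open chain rather than a ring replaced the same group. Going by these compounds, a rise in this assay is therefore expected for compound 3, estimated as a 250-fold higher number from compound 1 to compound 3 (2.40 log units; beyond the scatter), though whether a five-membered ring matches an open chain is untested. The estimate for compound 3 is 50 ug/mL, between 10 ug/mL and 200 ug/mL.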

Compound 3, solubility: 5.34 ug/mL
For compound 3 the middle estimate is 9.4-fold (0.97 log units) above the measured one; measured number outside the range, below it.
By their numbers in this assay, from the lowest: compound 1; then compound 3; then compound 2.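

In this assay the group on the carbonyl carbon matters even when a ring is kept: a non-aromatic ring in place of the aromatic one gives a 27-fold higher number from compound 1 to compound 3 (1.43 log units; beyond the scatter) in this comparison. Yet cyclopentyl does not behave like the open chain, since replacing sec-butyl gives a 19-fold lower number from compound 2 to compound 3 (1.29 log units; beyond the scatter) and the two groups are not interchangeable here. Nothing available explains either step.

With a single ring and a single chain compared, no trend with ring size or chain shape can be drawn. Going by these compounds, how a cyclohexyl ring, a longer chain or an amine on this carbonyl carbon would behave remains open.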